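A few compounds are considered here, and "the series" means these few. Any claim that something is new, unique, unknown or untested is made for them only; others in the source may bear on it.

Measured in a functional assay on DU-145 cells (Homo sapiens) for inhibition, read by trypan blue exclusion, with a stated time of 96 h; a higher number here means a weaker inhibitor of growth, a lower number a stronger inhibitor of growth:
- compound 1 `O=C(O)c1ccc(C(=O)/C(=C\c2ccc(F)c([N+](=O)[O-])c2)SCc2ccc(Cl)cc2Cl)cc1` gives 1000 nM
- compound 2 `O=C(O)c1ccc(C(=O)/C(=C\c2ccc(Cl)c([N+](=O)[O-])c2)SCc2ccc(C(F)(F)F)cc2)cc1` gives 1000 nM
- compound 3 `Cc1ccc(CS/C(=C/c2ccc(Cl)c([N+](=O)[O-])c2)C(=O)c2ccc(C(=O)O)cc2)cc1` gives 1000 nM

Compound 3 stands level with compounds 1 and 2, and the three values show no separation. The next structure is compound 4 `O=C(O)c1ccc(C(=O)/C(=C\c2ccc(Cl)c([N+](=O)[O-])c2)SCc2ccc(Cl)cc2Cl)cc1`, which differs from compound 3 as follows: 2,4-dichlorophenyl in place of 4-methylphenyl on a saturated chain carbon bound to a sulfur. This turns the (4-methylbenzyl)sulfanyl of compound 3 into (2,4-dichlorobenzyl)sulfanyl.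

For the measured compounds named here, only one measured step touches this part of the series: no change at the digits printed from compound 2 to compound 3 (within the scatter). It is a small piece of evidence, and it lies within the scatter. The (2,4-dichlorobenzyl)sulfanyl also occurs in compound 1, which gives 1000 nM. Going by the values given here, no measured compound shows this exact replacement on its own, so the basis is thin. Among the compounds with values here, nothing measured so far points to a shift in either direction in this assay.

The expected result is no movement beyond the scatter, with an estimated no change at the digits printed from compound 3 to compound 4 (within the scatter). For compound 4 the estimated value is 1000 nM, with an expected range of 500 nM to 2000 nM.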

Compound 4, concentration for 50% growth inhibition: 1000 nM
The estimate for compound 4 equals the measured number at the digits printed, within the range that was stated.
By their numbers in this assay, from the lowest: compounds 1, 2, 3 and 4 (each within the scatter of the next).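

In this assay, 2,4-dichlorophenyl on the saturated chain carbon bound to a sulfur gives no change at the digits printed from compound 3 to compound 4 (within the scatter), and against 4-(trifluoromethyl)phenyl at the same place it gives no change at the digits printed from compound 2 to compound 4 (within the scatter), so three different aromatic groups there now read alike. The other single change, chloro in place of fluoro on an aromatic carbon with the (2,4-dichlorobenzyl)sulfanyl held fixed, gives no change at the digits printed from compound 1 to compound 4 (within the scatter), which extends the flat reading to a second part of the molecule. No independent measurement is available to explain this flatness.

All four compounds share one value, so neither change has yet been seen to move growth inhibition. Going by these compounds, what an amide in place of the carboxylic acid, or an amine in place of the chloro, would do remains open.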